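The source may hold more compounds than are shown below. What is called first, only, known or untested is meant among the compounds shown, and "the series" means these compounds.

Measured compounds:
- compound 1 `CC(C)C1C(=O)N(C)c2cnc(Nc3ccc(S(N)(=O)=O)cc3)nc2N1C` — 254 nM
- compound 2 `CCc1ccccc1C1C(=O)N(C)c2cnc(Nc3ccc(S(N)(=O)=O)cc3)nc2N1C` — 51 nM
- compound 3 `COc1ccccc1C1C(=O)N(C)c2cnc(Nc3ccc(S(N)(=O)=O)cc3)nc2N1C` — 251 nM

In an assay on Sf9 cells for inhibition of serine/threonine-protein kinase 4 (Homo sapiens), read by luminescence and ADP-Glo, with a stated time of 1 h, in the presence of a further agent that is not named here (a lower number here means a stronger inhibitor, a higher number a weaker inhibitor), compound 3 stands second highest of the three numbers; its nearest neighbour is compound 1, with the gap a 1.0-fold lower number from compound 1 to compound 3 (0.01 log units; within the scatter) lying within the scatter, and the furthest is compound 2, reached by a 4.9-fold higher number from compound 2 to compound 3 (0.69 log units; beyond the scatter).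

Compound 4 `Cc1c(F)cccc1C1C(=O)N(C)c2cnc(Nc3ccc(S(N)(=O)=O)cc3)nc2N1C` carries the change (3-fluoro-2-methylphenyl in place of 2-methoxyphenyl on a saturated ring carbon). Among the measured compounds shown here, the steps that bear on it are the two that vary the group on the same saturated ring carbon: a 5.0-fold lower number from compound 1 to compound 2 (0.70 log units; beyond the scatter) and a 4.9-fold higher number from compound 2 to compound 3 (0.69 log units; beyond the scatter). Both point the same way, with the 2-ethylphenyl of compound 2 giving the lowest number of the three and the 2-methoxyphenyl of compound 3 sitting level with the isopropyl of compound 1. For the measured compounds named here, the 3-fluoro-2-methylphenyl of compound 4 shares an alkyl substituent on the aromatic ring with compound 2 rather than the methoxy of compound 3, so a lower number in this assay is expected, by roughly a 3.1-fold lower number from compound 3 to compound 4 (0.50 log units; beyond the scatter), though the added fluorine has no measured precedent here. Compound 4 is therefore estimated at 80 nM, with a range of 30 nM to 220 nM.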

Compound 4, half-maximal inhibitory concentration: 419 nM
Beside the measured number, compound 4's estimate is 5.2-fold (0.72 log units) below it, and the stated range ends below it.
By their numbers in this assay, from the lowest: compound 2; then compounds 3, 1 and 4 (each within the scatter of the next).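

In this assay, the 3-fluoro-2-methylphenyl group sits level with 2-methoxyphenyl (a 1.7-fold higher number from compound 3 to compound 4 (0.22 log units; within the scatter)) and with isopropyl (a 1.6-fold higher number from compound 1 to compound 4 (0.22 log units; within the scatter)), so an alkyl substituent on the aromatic ring does not by itself go with the low number of compound 2. The 2-ethylphenyl group now stands alone among the four groups at this saturated ring carbon, with an 8.2-fold higher number from compound 2 to compound 4 (0.91 log units; beyond the scatter) adding a third step beyond the scatter to those from its other two neighbours. No measurement here accounts for this gap.

Still open, going by these compounds, is whether the gap follows the length of the alkyl substituent, the added fluorine, or both. A plain 2-methylphenyl and a 2-propylphenyl at the same carbon would separate these readings.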